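The compounds below may be only part of what the source reports. "The series", "measured", "known", "first", "only" and "open" are said of these compounds alone.

Measured so far, in a functional assay on B16 cells (Mus musculus) for cytotoxicity, read by CCK-8 assay, with a stated time of 24 h; a lower number here means a stronger inhibitor, a higher number a weaker inhibitor:
- compound 1 `COc1ccccc1Oc1c(N)nc(-c2ccccc2)nc1Cl`: 4610 nM
- compound 2 `COc1ccccc1Oc1c(N)nc(-c2cccc(Cl)c2)nc1Cl`: 17900 nM
- compound 3 `COc1cccc(-c2nc(N)c(Oc3ccccc3OC)c(OCCO)n2)c1`: 30500 nM

Compound 3 has the highest of the three numbers; against compound 2 it sits within the scatter, against compound 1 beyond it.

Compound 4 `COc1ccccc1Oc1c(N)nc(-c2ccc(I)cc2)nc1OCCO` differs from compound 3 by 4-iodophenyl in place of 3-methoxyphenyl on an aromatic carbon.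

Among the compounds with values here, the one measured step that touches the same ring, a halogen entering the phenyl on the shared core, is a 3.9-fold higher number from compound 1 to compound 2 (0.59 log units; beyond the scatter). On that basis the iodo compound 4 is expected to give a somewhat higher number than compound 3, though the starting point is already weak and the shift may stay close to the scatter. The expected step is a 1.8-fold higher number from compound 3 to compound 4 (0.26 log units; within the scatter). Compound 4 is therefore estimated at 55000 nM, within 20000 nM to 150000 nM in this assay.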

Compound 4, half-maximal inhibitory concentration: 19600 nM
For compound 4 the middle estimate is 2.8-fold (0.45 log units) above the measured one; the whole stated range lies above it.
By their numbers in this assay, from the lowest: compound 1; then compounds 2, 4 and 3 (each within the scatter of the next).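

In this assay, 4-iodophenyl in place of 3-methoxyphenyl, on the aromatic carbon between two ring nitrogen atoms, gives a 1.6-fold lower number from compound 3 to compound 4 (0.19 log units; within the scatter). With the 2-hydroxyethoxy group present, this position therefore takes a swap of both substituent and its place on the phenyl without a change that stands clear of the scatter. No data on hand bear on this result. Still open, going by these compounds, is whether an amine or a longer chain in place of the 2-hydroxyethoxy group would move the number in this assay beyond the scatter with 4-iodophenyl kept.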